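Methoxycarbonyl Enters the Acetyl Chain of Compound 3

The source may hold more compounds than are shown below. What is called first, only, known or untested is meant among the compounds shown, and "the series" means these compounds.

Of the compounds shown here, three sharing one core have been measured in a functional assay on HCC1806 cells (Homo sapiens) for inhibition, read by sulforhodamine B assay, tested at 10 uM; on this read-out higher numbers stand for more inhibition at the one concentration tested (going by the name of the read-out) and lower numbers for less inhibition. Compound 1 `CC(=O)N1N=C(c2ccc(N3CCN(C)CC3)cc2)CC1c1ccc(N(C)C)cc1` gives -0.8%, compound 2 `COC(=O)CC(=O)N1N=C(c2ccc(N3CCN(C)CC3)cc2)CC1c1ccc(N(C)C)cc1` gives -8.3%, and compound 3 `CC(=O)N1N=C(c2ccc(-n3cncn3)cc2)CC1c1ccc(N(C)C)cc1` gives 11%. Compound 3 stands highest of the three numbers, separated from compound 1 by a number 11.8 percentage points higher from compound 1 to compound 3 (beyond the scatter) and lying further still from compound 2. Compound 4 `COC(=O)CC(=O)N1N=C(c2ccc(-n3cncn3)cc2)CC1c1ccc(N(C)C)cc1` differs from compound 3 by methoxycarbonyl in place of hydrogen on a saturated chain carbon bound to a carbonyl carbon. The same change has been measured once before, as a number 7.5 percentage points lower from compound 1 to compound 2 (within the scatter), a step within the scatter; nothing else in these data bears on it. The expected step is accordingly a number 6 percentage points lower from compound 3 to compound 4 (within the scatter), none beyond the scatter. For compound 4 the value in this assay is estimated at 5%, with a range from -9% to 19%.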

Compound 4, a percentage reported as inhibition, at one concentration (the size of the read-out at that concentration, not a potency): -7.8%
Beside the measured number, compound 4's estimate is 12.8 percentage points above it; the range from low to high includes it.
By their numbers in this assay, from the lowest: compounds 2, 4 and 1 (each within the scatter of the next); then compound 3.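

On the core carrying 1H-1,2,4-triazol-1-yl, methoxycarbonyl in place of hydrogen gives a number 18.8 percentage points lower from compound 3 to compound 4 (beyond the scatter), so a change that had stayed within the scatter now passes it, yet the two readings still agree: the same change on two cores in this assay, a number 7.5 percentage points lower (within the scatter) from compound 1 to compound 2 and a number 18.8 percentage points lower (beyond the scatter) from compound 3 to compound 4, 11.3 percentage points apart, within the scatter of two such steps.

With methoxycarbonyl present, 1H-1,2,4-triazol-1-yl in place of 4-methylpiperazin-1-yl gives only a number 0.5 percentage points higher from compound 2 to compound 4 (within the scatter), so the earlier step beyond the scatter is not repeated, though these two readings also agree: the same change on two cores in this assay, a number 11.8 percentage points higher (beyond the scatter) from compound 1 to compound 3 and a number 0.5 percentage points higher (within the scatter) from compound 2 to compound 4, 11.3 percentage points apart, within the scatter of two such steps.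

On these data alone, what a carboxylic acid or a longer alkyl chain would do on this saturated chain carbon stays open.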